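A few compounds are considered here, and "the series" means these few. Any claim that something is new, unique, unknown or untested is made for them only; others in the source may bear on it.

Measured in an in vivo ADME assay on the whole organism (Rattus norvegicus) for pharmacokinetics; on this read-out lower numbers stand for lower oral bioavailability and higher numbers for higher oral bioavailability:
- compound 1 `COCC1=C(C(=O)NCCCN2CCC(c3ccc(F)cc3)CC2)[C@@H](c2ccc(F)c(F)c2)NC(=O)N1`: 26%
- compound 2 `N#Cc1cc(F)ccc1C1CCN(CCCNC(=O)C2=CNC(=O)N[C@@H]2c2ccc(F)c(F)c2)CC1`: 0%

Compound 2 holds the lower of the two numbers, and its gap to compound 1 lies beyond the scatter. Compound 3 `COCC1=C(C(=O)NCCCN2CCC(c3ccc(F)cc3C#N)CC2)[C@@H](c2ccc(F)c(F)c2)NC(=O)N1` has not yet been measured. It differs from compound 2 in one place: methoxymethyl in place of hydrogen on a double-bonded ring carbon.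

For the measured compounds named here, no measured pair isolates this change. Going by the values given here, the only guide is that methoxymethyl also occurs in compound 1, which gives 26% in this assay. Compound 1 lacks the nitrile shared by compound 2 and compound 3, which makes it a loose guide. Compound 2 gives 0%, and a rise beyond the scatter is expected from this starting point, though probably not to the full level of compound 1. The expected change is a number 18 percentage points higher from compound 2 to compound 3 (beyond the scatter). For compound 3 the estimated oral bioavailability is 18%, with an expected range of 4% to 38%.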

Compound 3, oral bioavailability: < 6%
Compound 3: a limit, no number (the forecaster's own chance of this, stated with the estimate: 5%); middle value at least 12 percentage points from the limit.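

In this assay, compound 3 gives < 6%, which is a limit and not a number. For the compounds shown here, the step that puts methoxymethyl in place of hydrogen on the double-bonded ring carbon of compound 2 cannot be read, so this change at this position still has no size: the limit of < 6% in this assay, at which 1 of the 3 values shown sits. The one readable step in this set concerns the other place, where cyano in place of hydrogen on an aromatic carbon, with methoxymethyl present in both compounds, comes with a number at least 20 percentage points lower from compound 1 to compound 3 (beyond the scatter), so in this pair methoxymethyl on the ring carbon does not by itself hold the read-out at the level of compound 1.

On these data alone, it remains open what the cyano change does when hydrogen rather than methoxymethyl sits on the double-bonded ring carbon, and so whether the two changes act independently of each other in this assay. As far as these compounds go, it is also open whether a methyl group, a hydroxymethyl group or an aminomethyl group on that carbon, with the nitrile kept, would give a readable number rather than a limit.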